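A few compounds are considered here, and "the series" means these few. Any claim that something is new, unique, unknown or untested is made for them only; others in the source may bear on it.

Compound 1 `CCCc1nnc(SCc2ccccc2)n1N1C(=O)c2ccccc2C1=O` in a functional assay on A549 cells (Homo sapiens) for cytotoxicity, read by MTT assay, with a stated time of 48 h (on this read-out higher numbers stand for weaker inhibition and lower numbers for stronger inhibition), gives > 200000 nM, which is a limit of the assay and not a number.
Compound 2 `C#CCSc1nnc(CCC)n1N1C(=O)c2ccccc2C1=O` gives > 200000 nM, again a limit.
Compound 3 `CCCc1nnc(SCc2ccccc2Cl)n1N1C(=O)c2ccccc2C1=O` gives > 200000 nM, also a limit.

Compound 3 thus stands only at a limit in this assay, as do the other two compounds; all three values sit at the limit of > 200000 nM in this assay, at which 3 of the 3 values shown sit. The change from compound 3 to compound 4 `CCCc1nnc(SCC(=O)c2ccccc2)n1N1C(=O)c2ccccc2C1=O` is benzoyl in place of 2-chlorophenyl on a saturated chain carbon bound to a sulfur. Among the measured compounds shown here, the steps that bear on it, a step that the two limits leave unreadable from compound 1 to compound 2, a step that the two limits leave unreadable from compound 1 to compound 3 and a step that the two limits leave unreadable from compound 2 to compound 3, all alter the same position, yet none has a readable size, each running between two limits. For the measured compounds named here, no measured step yields a size or a direction for this change in this assay. The step from compound 3 to compound 4 is expected to be a number no higher from compound 3 to compound 4 (the limit leaves the size open), most likely ending again at a limit. Compound 4 is estimated at 200000 nM, within 50000 nM to 600000 nM.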

Compound 4, half-maximal inhibitory concentration: > 200000 nM
Compound 4: no number, only a limit; the forecaster's own chance of this, stated with the estimate: 80%; the middle value sits exactly at the limit.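

Compound 4, like compound 1, compound 2 and compound 3, stands only at a limit in this assay, so no step among them can be read: the limit of > 200000 nM in this assay, at which 4 of the 4 values shown sit.

The compounds shown leave open whether any group on a saturated chain carbon bound to a sulfur changes this read-out at all.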